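A few compounds are considered here, and "the series" means these few. Any claim that something is new, unique, unknown or untested is made for them only; others in the source may bear on it.

Three compounds share one core. Compound 1 `CC(C)(N)CC(=O)N[C@@H]1CCc2ccccc2N(Cc2ccc(-c3ccccc3C(=O)O)cc2)C1=O` gives 3 uM in a functional assay (Pituitary gland cell) with Rattus norvegicus as the target; on this read-out lower numbers stand for an effect already at smaller amounts and higher numbers for an effect only at larger amounts of compound; compound 2 `CC(O)Cn1nnc(-c2ccccc2-c2ccc(CN3C(=O)[C@H](NC(=O)CC(C)(C)N)CCc4ccccc43)cc2)n1` gives 0.05 uM; compound 3 `CC(C)(N)CC(=O)N[C@@H]1CCc2ccccc2N(Cc2ccc(-c3ccccc3S(=O)(=O)NC(C)(C)C)cc2)C1=O` gives 4 uM. Compound 3 stands at the highest number of the three: one of its two gaps is a 1.3-fold higher number from compound 1 to compound 3 (0.12 log units; within the scatter) and so lies within the scatter, whereas the other is an 80-fold higher number from compound 2 to compound 3 (1.90 log units; beyond the scatter), far beyond it. The one large step among these three, a 60-fold lower number from compound 1 to compound 2 (1.78 log units; beyond the scatter), concerns the group on the aromatic carbon, not the sulfonamide.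

Compound 4 `CC(C)(N)CC(=O)N[C@@H]1CCc2ccccc2N(Cc2ccc(-c3ccccc3S(N)(=O)=O)cc2)C1=O` differs from compound 3 by hydrogen in place of tert-butyl on a sulfonamide nitrogen. Going by the values given here, no measured step touches this position; the steps on record all exchange the whole group on the aromatic carbon and do not tell how a change on the sulfonamide nitrogen alone behaves. Among the compounds with values here, with no step to lean on, the expectation for compound 4 is a change of about no change at the digits printed from compound 3 to compound 4 (within the scatter), that is, nothing beyond the scatter. Compound 4 is therefore estimated at 4 uM, with a range from 1.3 uM to 12 uM.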

Compound 4, concentration for half-maximal effect: 3 uM
Estimate against measurement, compound 4: 1.3-fold (0.12 log units) above; low and high end bracket the measured number.
By their numbers in this assay, from the lowest: compound 2; then compounds 1, 4 and 3 (each within the scatter of the next).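

Hydrogen in place of tert-butyl on the sulfonamide nitrogen, the first change confined to this position, stays within the scatter in this assay (a 1.3-fold lower number from compound 3 to compound 4 (0.12 log units; within the scatter)), so the tert-butyl is dispensable for this read-out in this pair. Sulfamoyl and carboxy on the aromatic carbon also cannot be separated (no change at the digits printed from compound 1 to compound 4 (within the scatter)), whereas the gap to the tetrazole remains large (a 60-fold higher number from compound 2 to compound 4 (1.78 log units; beyond the scatter)), leaving 2-(2-hydroxypropyl)-2H-tetrazol-5-yl as the only group among these four compounds that stands apart. No evidence here accounts for either result.

Other groups on the sulfonamide nitrogen, such as methyl or a 2-hydroxypropyl chain, remain open. Also open, as far as these compounds go, is how the unsubstituted tetrazole compares with compound 2, which would show what the 2-hydroxypropyl chain contributes.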